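Trifluoromethoxy for Trifluoromethyl on a Single Measured Compound

The source may hold more compounds than are shown below. What is called first, only, known or untested is meant among the compounds shown, and "the series" means these compounds.

For the measured compounds named here, only one number anchors this small series so far. In a functional assay on NALM-6 cells (Homo sapiens) for cytotoxicity, read by luminescence and CellTiter-Glo, with a stated time of 3 days (on this read-out lower numbers stand for stronger inhibition and higher numbers for weaker inhibition), compound 1 (`O=C(Nc1ccccc1)c1cc(F)ccc1O`) has the entry "not determined" (no result reported) and so offers no comparison. Going by the values given here, compound 2 (`O=C(Nc1cccc(C(F)(F)F)c1)c1cc(F)ccc1O`) gives 1800 nM as the only number available, so it cannot yet be ranked as strong or weak. Compound 3 (`O=C(Nc1cccc(OC(F)(F)F)c1)c1cc(F)ccc1O`) keeps the shared core and differs from compound 2 in one group (trifluoromethoxy in place of trifluoromethyl on an aromatic carbon), with trifluoromethoxy in place of trifluoromethyl on an aromatic carbon. Among the compounds with values here, no measured step exists to guide the size of this change, so no shift beyond the usual scatter is expected in this assay in either direction. The estimated step of a 1.1-fold lower number from compound 2 to compound 3 (0.02 log units; within the scatter) stays within that scatter. Compound 3 is estimated at 1700 nM (range 600 nM to 4500 nM).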

Compound 3, half-maximal inhibitory concentration: 1370 nM
Estimate against measurement, compound 3: 1.2-fold (0.09 log units) above, and the stated range covers the measured number.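

For the compounds shown here, the change from trifluoromethyl to trifluoromethoxy gives the first measured step at this position in this assay (a 1.3-fold lower number from compound 2 to compound 3 (0.12 log units; within the scatter)). On this aromatic carbon, then, the entering group, with its extra oxygen and its one hydrogen-bond acceptor, gives a number that cannot be told apart from that of the group it replaces. Nothing measured here explains this result or shows what either group contributes.

Compound 1 stands at "not determined" (no result reported) and so steps to it cannot be read, which leaves open whether having either fluorinated group at this place matters at all. Also open, going by these compounds, is whether an amine, a carboxylic acid or a longer chain such as ethoxy on this carbon would move the number beyond the usual scatter.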